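Ethoxycarbonyl for cyano: expected standing of compound 4

The source may hold more compounds than are shown below. What is called first, only, known or untested is meant among the compounds shown, and "the series" means these compounds.

compound 1 `Cc1cc(NNC(=O)Nc2cc(Cl)nc(Cl)c2)ncc1N(C)C` — in a functional assay on CHO cells for agonist activity at sphingosine 1-phosphate receptor 2 (Homo sapiens), read by fluorescence and calcium flux, with a stated time of 3 min (a lower number here means a stronger inhibitor, a higher number a weaker inhibitor), compound 1 gives > 23000 nM, a limit of the assay.
compound 2 `Cc1cc(NNC(=O)Nc2cc(Cl)nc(Cl)c2)ncc1C#N` — in this assay compound 2 gives > 23000 nM, a limit of the assay.
compound 3 `Cc1cc(C#N)nc(NNC(=O)Nc2cc(Cl)nc(Cl)c2)c1` — in this assay compound 3 gives > 23000 nM, a limit of the assay.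

Compound 3 stands only at a limit in this assay; no number is known for it, and the two other measured compounds stand at the same place, since (the limit of > 23000 nM in this assay, at which 3 of the 3 values shown sit). Going by the values given here, the single step between measured compounds, a step that the two limits leave unreadable from compound 1 to compound 2, is therefore unreadable in size. Compound 4 `CCOC(=O)c1cc(C)cc(NNC(=O)Nc2cc(Cl)nc(Cl)c2)n1` differs from compound 3 by ethoxycarbonyl in place of cyano on an aromatic carbon. Among the compounds with values here, no measured step bears on this change: the only comparison available cannot be sized, and the change itself has no measured counterpart. What the three values show is that nothing tried so far has produced a readable number in this assay. Compound 4 is expected to give 30000 nM, with a range from 10000 nM to 100000 nM, and most likely to be reported as a limit again. This expectation amounts to a step that the limit leaves unreadable from compound 3 to compound 4, no change beyond the scatter.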

Compound 4, half-maximal inhibitory concentration: > 23000 nM
Compound 4 was reported as a limit (the forecaster's own chance of this, stated with the estimate: 85%); the middle value lies beyond the limit too.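

No step can be read from compound 3 to compound 4, since both stand at a limit: the limit of > 23000 nM in this assay, at which 4 of the 4 values shown sit.
Still open, as far as these compounds go, is whether ethoxycarbonyl and cyano differ at all in this assay and whether any compound of this series gives a readable number there.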